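The source may hold more compounds than are shown below. What is called first, only, known or untested is meant among the compounds shown, and "the series" means these compounds.

In an ADME assay on HEK293 cells (Homo sapiens) for cytotoxicity, read by ATP content, with a stated time of 6 h (a lower number here means that less compound is tolerated, a higher number that more compound is tolerated), three compounds built on a shared core have been tested so far. Compound 1 `CCCCNc1nc(N)nc2ccn(CCCc3ccccc3)c12` gives > 24000 nM, which is a limit of the assay and not a number. Compound 2 `CCCCNc1nc(N)nc2ccn(Cc3ccsc3)c12` gives > 24000 nM, again a limit. Compound 3 `CCCCNc1nc(N)nc2ccn(Cc3ccccn3)c12` gives > 24000 nM, also a limit, so it has no exact position on the scale.

Compound 4 `CCCCNc1nc(N)nc2ccn(Cc3cccnc3)c12` has the same atoms as compound 3, joined differently: pyridin-3-yl in place of pyridin-2-yl on a saturated chain carbon bound to an aromatic nitrogen. In words, pyridin-3-yl stands in place of pyridin-2-yl on a saturated chain carbon bound to an aromatic nitrogen.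

The closest measured changes swap this same side group, but their sizes cannot be read. They are a step that the two limits leave unreadable from compound 1 to compound 2, a step that the two limits leave unreadable from compound 1 to compound 3 and a step that the two limits leave unreadable from compound 2 to compound 3. What they do show is the limit of > 24000 nM in this assay, at which 3 of the 3 values shown sit. On that basis, no step beyond the usual scatter is expected in this assay, in either direction. The expected change is a step that the limit leaves unreadable from compound 3 to compound 4. For compound 4 the estimated value is 30000 nM, with an expected range from 18000 nM to 60000 nM.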

Compound 4, half-maximal cytotoxic concentration: > 24000 nM
Compound 4 gave a limit, no number; the forecaster's own chance of this, stated with the estimate: 90%; the middle value lies beyond the limit too.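

In this assay compound 4 gives > 24000 nM, which is a limit and not a number. Its steps from compound 1, compound 2 and compound 3 therefore cannot be read. The compounds shown leave open whether any side group on the shared core changes how much compound is tolerated, as all share one ceiling: the limit of > 24000 nM in this assay, at which 4 of the 4 values shown sit.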